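The source may report more compounds than this note shows. Statements on the series, on what has been measured and on what is new or still open speak of the compounds shown alone.

Among the measured compounds shown here, in a functional assay on NCI/ADR-RES cells (Homo sapiens) for inhibition, read by sulforhodamine B assay, with a stated time of 48 h (a higher number here means a weaker inhibitor of growth, a lower number a stronger inhibitor of growth), compound 1 `CC1(/C=C/c2ccccc2)C=CC(=O)O1` gives 414000 nM and holds the higher of the two numbers so far, while compound 2 `COc1ccccc1/C=C/C1(C)C=CC(=O)O1` gives 64500 nM as the lower one. For the measured compounds named here, compound 3 `COc1ccc(/C=C/C2(C)C=CC(=O)O2)cc1` has not been measured and differs from compound 1 by methoxy in place of hydrogen on an aromatic carbon as its one change. Going by the values given here, the only measured step of this kind, methoxy in place of hydrogen on an aromatic carbon, is a 6.4-fold lower number from compound 1 to compound 2 (0.81 log units; beyond the scatter) and it stands alone as a guide. A step in the same direction, of similar or somewhat smaller size, is therefore expected in this assay and is estimated as a 3.8-fold lower number from compound 1 to compound 3 (0.58 log units; beyond the scatter) from that single example. For compound 3 the estimated value is 110000 nM with an expected range from 35000 nM to 300000 nM around it.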

Compound 3, concentration for total growth inhibition: > 1000000 nM
Compound 3 was reported as a limit; the forecaster's own chance of this, stated with the estimate: 5%; middle value at least 9.0-fold (0.95 log units) from the limit.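

Methoxy in place of hydrogen does not act the same way everywhere on the six-membered aromatic ring: placed para to a group of 9 heavy atoms, it gives an at least 2.4-fold higher number from compound 1 to compound 3 (0.38 log units; beyond the scatter), opposite in direction to a 6.4-fold lower number from compound 1 to compound 2 (0.81 log units; beyond the scatter). Among these compounds, then, the outcome of this change depends on where the methoxy sits. For compound 3, > 1000000 nM is a limit and not a number in this assay: the limit of > 1000000 nM in this assay, at which 1 of the 3 values shown sits. On these data alone, whether an amine, a carboxylic acid or a longer chain such as ethoxy at this position would follow the methoxy remains open.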